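A few compounds are considered here, and "the series" means these few. Any claim that something is new, unique, unknown or untested is made for them only; others in the source may bear on it.

Measured in an ADME assay on microsomes from liver (Mus musculus) for metabolic stability, with a stated time of 10 min; a lower number here means that less of the compound is left, a higher number that more of the compound is left:
- compound 1 `O=C(O)C1CCC(O)(C(=O)N2CC[C@](c3ccc(C(F)(C(F)(F)F)C(F)(F)F)cc3)(S(=O)(=O)c3ccc(F)cc3)C2)CC1`: 99%; 98% (2 entries)
- compound 2 `O=C(O)C12CCC(C(=O)N3CC[C@](c4ccc(C(F)(C(F)(F)F)C(F)(F)F)cc4)(S(=O)(=O)c4ccc(F)cc4)C3)(CC1)C2`: "not determined" (no result reported)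
- compound 3 `COC(=O)[C@H]1CC[C@H](C(=O)N2CC[C@](c3ccc(C(F)(C(F)(F)F)C(F)(F)F)cc3)(S(=O)(=O)c3ccc(F)cc3)C2)CC1`: "not determined" (no result reported)

Only compound 1 has a number here, and its repeat readings agree closely: the several entries of compound 1 in this assay, 99%; 98% (2 entries). Compound 3 has no result, so it offers no starting value, and neither does compound 2.

The next compound, compound 4 `O=C(N1CC[C@](c2ccc(C(F)(C(F)(F)F)C(F)(F)F)cc2)(S(=O)(=O)c2ccc(F)cc2)C1)C1(O)CCS(=O)(=O)CC1`, keeps the shared core but changes the group on the carbonyl carbon. The step is 4-hydroxy-1,1-dioxothian-4-yl in place of 4-(methoxycarbonyl)cyclohexyl on a carbonyl carbon. In words, 4-hydroxy-1,1-dioxothian-4-yl takes the place of 4-(methoxycarbonyl)cyclohexyl.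

For the measured compounds named here, no measured step shows what such a swap does, so the expectation rests on a single neighbour and remains uncertain. Compound 1 shares the core and reaches 99%; 98% (2 entries), close to the top of the scale. Compound 4 is therefore expected to stay near that level, with no difference beyond the usual scatter or perhaps a modest drop. In this assay, the estimate for compound 4 is an expected 92%, within an estimated range from 75% to 100%.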

Compound 4, percent of the compound remaining: 90%
Estimate against measurement, compound 4: 2 percentage points above; the range from low to high includes it.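

No step can be read for compound 4 in this assay: its nearest partner, compound 3, has no number there. What the compounds shown leave open is how replacing 4-(methoxycarbonyl)cyclohexyl with 4-hydroxy-1,1-dioxothian-4-yl, taken alone, changes the percent of compound remaining.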